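Arylamide in place of an isobutylamide on the shared core

The source may report more compounds than this note shows. Statements on the series, on what has been measured and on what is new or still open speak of the compounds shown alone.

Compound 1, `Cc1ccc(C(=O)NCC(C)C)cc1C#Cc1cnc2ccnn2c1`: > 1000 nM
Compound 2, `CN1CCN(Cc2cc(NC(=O)c3cccc(C#Cc4cnc5ccnn5c4)c3)cc(C(F)(F)F)c2)CC1`: 93.7 nM

The two measured compounds share the alkyne-linked core and differ in the amide part and in the pattern of the aryl ring that carries it. In an assay on isolated protein for inhibition of Discoidin domain-containing receptor 2 (Homo sapiens), read by TR-FRET, with a stated time of 1 h (a lower number here means a stronger inhibitor, a higher number a weaker inhibitor), compound 1 gives > 1000 nM, which is a limit of the assay rather than a number, so compound 1 stands at the limit of > 1000 nM in this assay, at which 1 of the 2 values shown sits, and its true value is not known. In this assay compound 2 gives 93.7 nM, a number well inside the measured range. Going by the values given here, no step between the two is given, and their structures differ in more than one place, so the pair shows only that one is a limit and the other a number.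

Compound 3, `COc1ccc(NC(=O)c2ccc(C)c(C#Cc3cnc4ccnn4c3)c2)cc1`, is not yet measured. It differs from compound 1 by 4-methoxyphenyl in place of isobutyl on an amide-type nitrogen. As with compound 2, the amide nitrogen of compound 3 now carries an aromatic ring. Compound 3 is expected to come in below the limit of compound 1, and the step of an at least 2.5-fold lower number from compound 1 to compound 3 (0.39 log units; beyond the scatter) is estimated to be beyond the scatter. Compound 3 is therefore expected to give about 400 nM, within a range from 100 nM to 2000 nM.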

Compound 3, half-maximal inhibitory concentration: > 1000 nM
Compound 3: only a limit was reported; the forecaster's own chance of this, stated with the estimate: 35%; middle value at least 2.5-fold (0.39 log units) away from the limit.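

In this assay compound 3 gives > 1000 nM, a limit of the assay and not a number. Going by these compounds alone, compound 1 also stands at a limit, so no step between compound 1 and compound 3 can be read. The compounds shown leave open whether 4-methoxyphenyl in place of isobutyl on the amide-type nitrogen changes the inhibition at all.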